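Working notes: from compound 3 to compound 4

A few compounds are considered here, and "the series" means these few. Any claim that something is new, unique, unknown or untested is made for them only; others in the source may bear on it.

Measured in a functional assay on SEM cells (Homo sapiens) for cytotoxicity, with a stated time of 72 h; on this read-out lower numbers stand for an effect already at smaller amounts and higher numbers for an effect only at larger amounts of compound; each entry is a limit and not a number:
- compound 1 `C=C[C@@](C)(/C=C/c1ccc(OC)cc1)CCC=C(C)C`: > 36600 nM
- compound 2 `C=C[C@@](C)(/C=C/c1ccc(OCc2ccccc2)cc1)CCC=C(C)C`: > 36600 nM
- compound 3 `C=C[C@@](C)(/C=C/c1ccc(Nc2ccc(F)c(F)c2)cc1)CCC=C(C)C`: > 36600 nM

Compound 3 gives > 36600 nM, which is a limit. It has no measured number in this assay, and neither of the other two compounds offers one for comparison. The three share (the limit of > 36600 nM in this assay, at which 3 of the 3 values shown sit).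

Compound 4 `C=C[C@@](C)(/C=C/c1ccc(Nc2c(F)cc(F)cc2F)cc1)CCC=C(C)C` carries 2,4,6-trifluorophenyl in place of 3,4-difluorophenyl on a nitrogen on an aromatic ring.

The measured steps that bear on this change are a step that the two limits leave unreadable from compound 1 to compound 3 and a step that the two limits leave unreadable from compound 2 to compound 3. The remaining one is a step that the two limits leave unreadable from compound 1 to compound 2. None of them replaces one fluorinated phenyl group with another, and none has a readable size. No size or direction can be carried over to the new change because of the limit of > 36600 nM in this assay, at which 3 of the 3 values shown sit. The most likely outcome is that the assay again reports only a limit, and no direction is expected. The expected outcome is a step that the limit leaves unreadable from compound 3 to compound 4, an estimate that rests on very little. The estimated value for compound 4 is 40000 nM, with an expected range from 20000 nM to 80000 nM.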

Compound 4, half-maximal effective concentration: > 36600 nM
Compound 4: a limit, no number (the forecaster's own chance of this, stated with the estimate: 80%); the middle value is on the limit's open side.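

In this assay compound 4 gives > 36600 nM, which is a limit and not a number. The step between compound 3 and compound 4 therefore cannot be read in size or direction: the limit of > 36600 nM in this assay, at which 4 of the 4 values shown sit.

The compounds shown leave open whether any group on the shared core gives a measurable number in this assay.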